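Trifluoromethyl in place of methyl: compound 1 to compound 4

A few compounds are considered here, and "the series" means these few. Any claim that something is new, unique, unknown or untested is made for them only; others in the source may bear on it.

Measured in a functional assay on A549 cells (Homo sapiens) for antiproliferative activity, read by MTT assay, with a stated time of 72 h (on this read-out lower numbers stand for stronger inhibition and higher numbers for weaker inhibition), so far:
compound 1 `Cc1ccc(S(=O)(=O)NC(=N)N2CCN(c3cc4c(cc3F)c(=O)c(C(=O)O)cn4C3CC3)CC2)cc1` gives 71 nM
compound 2 `CCn1cc(C(=O)O)c(=O)c2cc(F)c(N3CCN(C(=N)NS(=O)(=O)c4ccccc4Cl)CC3)cc21` gives 71 nM
compound 3 `CCn1cc(C(=O)O)c(=O)c2cc(F)c(N3CCN(C(=N)NS(=O)(=O)c4ccccc4)CC3)cc21` gives 71 nM

Compound 1 stands level with compound 2 and compound 3 in this assay and the three values offer no spread to work from. The next compound, compound 4 `N=C(NS(=O)(=O)c1ccc(C(F)(F)F)cc1)N1CCN(c2cc3c(cc2F)c(=O)c(C(=O)O)cn3C2CC2)CC1` keeps the core of compound 1 and has trifluoromethyl in place of methyl on an aromatic carbon so that 4-methylphenyl becomes 4-(trifluoromethyl)phenyl. The group sits on a six-membered aromatic ring of carbon only, para to a large group.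

Going by the values given here, only one measured step bears on this change, and only indirectly. It is no change at the digits printed from compound 2 to compound 3 (within the scatter) with hydrogen in place of chloro on an aromatic carbon. Among the compounds with values here, that step swaps a different pair of groups, and no compound measured so far carries trifluoromethyl, so the evidence is thin and the range has to stay wide. Nothing measured points to a direction. The step of a 1.0-fold lower number from compound 1 to compound 4 (0.01 log units; within the scatter) is therefore expected to stay within the scatter. For compound 4 the estimated value is 70 nM with an expected range of 28 nM to 180 nM in this assay as the working figure.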

Compound 4, half-maximal inhibitory concentration: 71 nM
For compound 4 the middle estimate is 1.0-fold (0.01 log units) below the measured one; the range from low to high includes it.
By their numbers in this assay, from the lowest: compounds 1, 2, 3 and 4 (each within the scatter of the next).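

In this assay, the place on the aromatic ring carrying methyl in compound 1 also accepts trifluoromethyl, with no change at the digits printed from compound 1 to compound 4 (within the scatter). This extends the earlier reading, which rested only on no change at the digits printed from compound 2 to compound 3 (within the scatter), to a second pair of groups and to a substituent of 4 heavy atoms in place of 1, so the larger, fluorine-bearing group leaves the value within the scatter at this place. No measurement at hand accounts for this flat result.

Still open, from the compounds shown here alone, is whether a group of another kind at this place, such as an amine, a carboxylic acid or a longer chain such as butyl, would carry the value in this assay beyond the scatter. Also open, going by these compounds, is whether trifluoromethyl in place of methyl reads the same on the core of compound 3, which has ethyl where compound 1 has cyclopropyl.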